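The source may report more compounds than this note shows. Statements on the series, on what has been measured and on what is new or still open speak of the compounds shown alone.

Compound 1 `CCSc1n[nH]c(-n2[se]c3ccccc3c2=O)n1` is tested in a functional assay on A549 cells (Homo sapiens) for antiproliferative activity, read by CCK-8 assay, with a stated time of 48 h (a higher number here means a weaker inhibitor, a lower number a stronger inhibitor), where compound 1 gives 39600 nM. That is the highest of the two plain numbers; its nearest neighbour is compound 3 `Cc1cccc(CSc2n[nH]c(-n3[se]c4ccccc4c3=O)n2)c1`, which in this assay gives 12400 nM, a step of a 3.2-fold lower number from compound 1 to compound 3 (0.50 log units; beyond the scatter). Compound 2 `Cc1ccc(CSc2n[nH]c(-n3[se]c4ccccc4c3=O)n2)cc1` reaches only a limit of the assay in this assay, > 50000 nM. The other steps read an at least 1.2-fold higher number from compound 1 to compound 2 (0.10 log units; that floor lies within the scatter) and an at least 4.0-fold lower number from compound 2 to compound 3 (0.60 log units; beyond the scatter). Compound 4 `CCCSc1n[nH]c(-n2[se]c3ccccc3c2=O)n1` differs from compound 1 by methyl in place of hydrogen on a saturated chain carbon, two bonds along the chain from a sulfur. All measured steps exchange the methyl for a 3-methylphenyl or 4-methylphenyl, so none speaks directly to a slightly longer chain. The step from compound 1 to compound 4 is therefore expected to be small, a 1.3-fold lower number from compound 1 to compound 4 (0.12 log units; within the scatter). Compound 4 is estimated at 30000 nM, within 12000 nM to 80000 nM.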

Compound 4, half-maximal inhibitory concentration: 45500 nM
Compound 4: middle estimate off by 1.5-fold (0.18 log units), on the low side; measured number inside the range.
By their numbers in this assay, from the lowest: compound 3; then compounds 1 and 4 (each within the scatter of the next). At a limit, above all of these: compound 2.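

Ethylsulfanyl and propylsulfanyl cannot be told apart in this assay (a 1.1-fold higher number from compound 1 to compound 4 (0.06 log units; within the scatter)), so the added methyl shows no effect that can be read. Within the data shown here, the 3-methylphenyl group remains the only change here that stands clear of these chains (a 3.7-fold higher number from compound 3 to compound 4 (0.56 log units; beyond the scatter)). One step rests on a limit and gives only a floor (an at least 1.0-fold lower number from compound 2 to compound 4 (0.04 log units; that floor lies within the scatter)). Compound 2 stands at a limit, not a number: the limit of > 50000 nM in this assay, at which 1 of the 4 values shown sits.

The compounds shown leave open whether a butyl chain, an unsubstituted phenyl or a chain carrying an amine would match the small chains or compound 3.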